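Aryl ureas: bromo in place of trifluoromethyl

The source may hold more compounds than are shown below. What is called first, only, known or untested is meant among the compounds shown, and "the series" means these compounds.

Measured compounds in an ADME assay on the whole organism with Oryza sativa as the target, tested at 0.1 uM; on this read-out lower numbers stand for a stronger effect and higher numbers for a weaker effect at the one concentration tested:
- compound 1, `C[C@@H](NC(=O)Nc1ccccc1C(F)(F)F)c1ccccc1`: 99%
- compound 2, `C[C@H](NC(=O)Nc1ccccc1C(F)(F)F)c1ccccc1`: 97%
- compound 3, `C[C@@H](NC(=O)Nc1cccc(Cl)c1)c1ccccc1`: 97%

Compound 1 has the highest of the three numbers, but neither neighbour is separated from it beyond the scatter. The step of a number 2 percentage points lower from compound 1 to compound 2 (within the scatter) rests on the fact that compounds 1 and 2 differ only in the configuration as drawn and shows that the configuration at the saturated chain carbon does not move the read-out. Compound 3 is not a single-point neighbour of compound 1. The number of compound 3, 97%, simply sits in the same band as compound 1.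

Compound 4, `C[C@@H](NC(=O)Nc1ccccc1Br)c1ccccc1`, differs from compound 1 by bromo in place of trifluoromethyl on an aromatic carbon. For the measured compounds named here, no measured step changes a substituent on that ring in one place, so the only step that bears on the question is a number 2 percentage points lower from compound 1 to compound 2 (within the scatter), and it is within the scatter. All three measured numbers lie close to the top of the scale, which leaves little room for a rise and gives no hint of a fall.

The step of a number 3 percentage points lower from compound 1 to compound 4 (within the scatter) is therefore expected to stay within the scatter. For compound 4 the expected value is 96%, with a range from 87% to 100%.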

Compound 4, a percentage reported as activity, at one concentration (the size of the read-out at that concentration, not a potency): 99%
Beside the measured number, compound 4's estimate is 3 percentage points below it; the measured number falls inside the stated range.
By their numbers in this assay, from the lowest: compounds 2, 3, 1 and 4 (each within the scatter of the next).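

In this assay, bromo in place of trifluoromethyl on an aromatic carbon, ortho to a large group, gives no change at the digits printed from compound 1 to compound 4 (within the scatter). This is the only step shown that changes a substituent on that ring in one place: the earlier step touched only the configuration at the saturated chain carbon, so the ring position had remained untested. The read-out does not separate a group of 4 heavy atoms (1 carbon, 3 fluorine) from a single bromine here, with compound 4 at 99% and still close to the top of the scale. The information available does not bear on why this exchange leaves the read-out in the same band.

Going by these compounds, whether an amine, a carboxylic acid or a longer chain on that aromatic carbon would bring the number clearly below this band remains open, since all the numbers shown sit together at the top of the scale. Also open, on these data alone, is whether bromo gives the same read-out with the stereocentre drawn as in compound 2.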